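Series notes: one aromatic fluoro removed

A few compounds are considered here, and "the series" means these few. Any claim that something is new, unique, unknown or untested is made for them only; others in the source may bear on it.

Measured so far:
compound 1 `CCC(C)(C)C(=O)N(O)Cc1ccc(F)cc1F`: 3.5 uL/min
compound 2 `CCC(C)(C)C(=O)N(O)Cc1cc(F)c(F)c(F)c1`: 10.5 uL/min

In an ADME assay on microsomes from liver (Homo sapiens) for metabolic stability, read by LC-MS, using NADPH (a lower number here means slower removal, a higher number faster removal of the compound), compound 2 gives the higher of the two numbers and compound 1 gives 3.5 uL/min, a gap beyond the scatter. Compound 3 `CCC(C)(C)C(=O)N(O)Cc1ccc(F)c(F)c1` is not yet measured. Its change from compound 2 is hydrogen in place of fluoro on an aromatic carbon. With one fluoro fewer, compound 3 is expected to sit between the two measured values, so a modest step downward is expected, a 1.6-fold lower number from compound 2 to compound 3 (0.21 log units; within the scatter), possibly within the scatter. For compound 3 the estimate in this assay is 6.5 uL/min, with a range from 3.5 uL/min to 12 uL/min.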

Compound 3, intrinsic clearance in a liver preparation (reported as CLH), per the amount of preparation that the assay uses: 6.5 uL/min
Beside the measured number, compound 3's estimate shows no gap at the digits printed, within the range that was stated.
By their numbers in this assay, from the lowest: compounds 1, 3 and 2 (each within the scatter of the next, the first and the last beyond it).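

For the compounds shown here, with hydrogen in place of fluoro on an aromatic carbon, ortho to a fluoro group and meta to a large group, this assay shows a 1.6-fold lower number from compound 2 to compound 3 (0.21 log units; within the scatter) as the first single-place step. Fluoro at this position therefore has no effect on the number that can be told apart from the scatter. No measurement bears on why this is so.

Still open, going by these compounds, is whether a methoxy group or an amine on this aromatic carbon would move the number in this assay clear of the scatter from compound 2.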